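The source may hold more compounds than are shown below. What is called first, only, known or untested is meant among the compounds shown, and "the series" means these compounds.

Measured so far in an ADME assay on MT4 cells (Homo sapiens) for cytotoxicity, read by MTT assay; a higher number here means that more compound is tolerated, a lower number that less compound is tolerated:
- compound 1 `Cc1cc(C)cc(S(=O)(=O)c2c(C(=O)Nc3ccccc3O)[nH]c3ccc(Cl)cc23)c1`: 19700 nM
- compound 2 `Cc1cc(C)cc(S(=O)(=O)c2c(C(=O)NCc3cccc(O)c3)[nH]c3ccccc23)c1`: > 5190 nM (a limit)
- compound 3 `Cc1cc(C)cc(S(=O)(=O)c2c(C(=O)NC(C)c3cccc(O)c3)[nH]c3ccc(Cl)cc23)c1`: 16000 nM

Among the measured compounds shown here, compound 3 sits at 16000 nM, within the scatter of compound 1, and these are the only two numbers so far. Compound 2 gives a limit and not a number.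

Compound 4 `Cc1cc(C)cc(S(=O)(=O)c2c(C(=O)NCc3ccc(O)c(O)c3)[nH]c3ccc(Cl)cc23)c1` is the next to be read. Its change from compound 3 is a group of 9 heavy atoms (7 carbon, 2 oxygen; one six-membered aromatic ring of carbon only) in place of a group of 9 heavy atoms (8 carbon, 1 oxygen; one six-membered aromatic ring of carbon only), on an amide-type nitrogen, with 3,4-dihydroxybenzyl entering on an amide-type nitrogen.

For the measured compounds named here, only one measured step bears on this, and it also changes the group on an amide-type nitrogen: a 1.2-fold lower number from compound 1 to compound 3 (0.09 log units; within the scatter). That step is small, so no step beyond the scatter is expected in this assay, although one step is thin support and the range is kept wide. The expected change is a 1.1-fold lower number from compound 3 to compound 4 (0.06 log units; within the scatter). For compound 4 the estimated value is 14000 nM, with an expected range of 6000 nM to 32000 nM.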

Compound 4, half-maximal cytotoxic concentration: 18300 nM
Beside the measured number, compound 4's estimate is 1.3-fold (0.12 log units) below it; measured number inside the range.
By their numbers in this assay, from the lowest: compounds 3, 4 and 1 (each within the scatter of the next).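

In this assay, a further change of the group on the amide-type nitrogen again gives no step beyond the scatter: a 1.1-fold higher number from compound 3 to compound 4 (0.06 log units; within the scatter), and a 1.1-fold lower number from compound 1 to compound 4 (0.03 log units; within the scatter). Compounds 1, 3 and 4 therefore show three different groups at this place with values within the scatter of each other, and the higher hydrogen-bond donor and acceptor counts of 3,4-dihydroxybenzyl come with no step beyond the scatter. Compound 2 gives only a limit and adds no number to this comparison: the limit of > 5190 nM in this assay, at which 1 of the 4 values shown sits.

On these data alone, whether an amine, a carboxylic acid or a longer chain on this nitrogen would give a step beyond the scatter remains open. The numbers shown also give no step for a change elsewhere on the shared core.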